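Trimming the pyrrolidine to an amine on a kinase core

The source may hold more compounds than are shown below. What is called first, only, known or untested is meant among the compounds shown, and "the series" means these compounds.

Of the compounds shown here, three of a shared core have been measured in an assay on isolated protein for inhibition of Leucine-rich repeat serine/threonine-protein kinase 2 (Homo sapiens), read by TR-FRET and LanthaScreen, with stated times of 50 min and 30 min, in the presence of a further agent that is not named here; on this read-out higher numbers stand for weaker inhibition and lower numbers for stronger inhibition. Compound 1 `Cn1c(N2CCCC2)c(C#N)c2c(N)ncnc21` gives 1480 nM. Compound 2 `Cc1cn(C)nc1Nc1cc2c(c(N)n1)c(C#N)c(N1CCC[C@H]1C)n2C` gives 2110 nM, a number that sits within the scatter of that of compound 1, so the two cannot be told apart. Compound 3 `Cc1c(Nc2nc(N)c3c(C#N)c(N4CCC[C@H]4C)n(C)c3n2)cnn1CC1(O)COC1` gives 16 nM, far lower than compound 1 and well beyond the scatter; that gap is the only clear difference seen so far, and it comes with a large added side group rather than a single small change. Compound 1 thus stands second highest of the three numbers, close to compound 2 and far above compound 3.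

Compound 4 `Cn1c(N)c(C#N)c2c(N)ncnc21` has not been measured. It differs from compound 1 in one place: amino in place of pyrrolidin-1-yl on an aromatic carbon. Among the compounds with values here, the pyrrolidin-1-yl ring is kept in both of the other measured compounds, so no measured pair shows what its removal does. The expectation is a step toward weaker inhibition, of moderate size and likely beyond the scatter, expressed as a 3.0-fold higher number from compound 1 to compound 4 (0.48 log units; beyond the scatter). On that basis compound 4 is estimated to give 4500 nM, with a range from 1200 nM to 17000 nM.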

Compound 4, half-maximal inhibitory concentration: 14400 nM
Compound 4: middle estimate off by 3.2-fold (0.51 log units), on the low side; the measured number falls inside the stated range.
By their numbers in this assay, from the lowest: compound 3; then compounds 1 and 2 (each within the scatter of the next); then compound 4.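

Within the data shown here, this pair is the first to isolate the group on this aromatic carbon of the shared core. In this assay, amino in place of pyrrolidin-1-yl gives a 9.7-fold higher number from compound 1 to compound 4 (0.99 log units; beyond the scatter), a clear weakening of inhibition, so the group held here matters to the number. Among these compounds, the exchange removes the ring and adds a hydrogen-bond donor at once, the single pair cannot separate these two changes, and nothing available gives a reason for the step.

Going by these compounds, it remains open whether a small open-chain amine such as dimethylamino, or a six-membered piperidine ring, would stay close to compound 1 or fall toward compound 4. Also open, on these data alone, is whether the same exchange would produce a step of similar size on a compound carrying the large side group of compound 3.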